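Fluoro removal on the indole core, compound 2 to compound 4

The source may hold more compounds than are shown below. What is called first, only, known or untested is meant among the compounds shown, and "the series" means these compounds.

Measured compounds:
- compound 1 `CCN1CCCC(n2cc(S(=O)(=O)c3ccccc3)c3ccccc32)C1`: 52%
- compound 2 `O=S(=O)(c1cccc(F)c1)c1cn(C2CCNC2)c2cccc(F)c12`: "not determined" (no result reported)
- compound 3 `COc1ccc2c(c1)c(S(=O)(=O)c1cccc(F)c1)cn2C1CCCN(C)C1`: "not determined" (no result reported)

In a functional assay on HeLa cells for agonist activity at 5-hydroxytryptamine receptor 6 (Homo sapiens), read by cAMP accumulation and immunoassay, with a stated time of 10 min (on this read-out lower numbers stand for smaller maximal responses and higher numbers for larger maximal responses), compound 1 reaches 52%, the only numerical result in the series. Compound 2 stands without a number: in this assay compound 2 is recorded as "not determined" (no result reported), and compound 3 likewise returns "not determined" (no result reported). For the measured compounds named here, no pair of measured compounds differs in one place, so no measured step exists against which the change below can be sized.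

Compound 4 `O=S(=O)(c1cccc(F)c1)c1cn(C2CCNC2)c2ccccc12` is the direct partner of compound 2. The change is hydrogen in place of fluoro on an aromatic carbon: a fluoro leaves and a hydrogen enters on an aromatic carbon of a six-membered aromatic ring of carbon only, part of a fused system of two rings, with no ring, donor, acceptor or charge affected. With compound 2 lacking a value, the direction of this step in this assay cannot be anchored; the expectation is a step of no size beyond the scatter, in no preferred direction. Compound 1 is the only reference for the maximal response of the shared core.

The maximal response of compound 4 in this assay is estimated at 50%, with a range from 20% to 90%.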

Compound 4, largest response reached (Emax), in percent of the reference or control that the assay uses: 38%
Compound 4: middle estimate off by 12 percentage points, on the high side; the measured number falls inside the stated range.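

No step can be read from compound 4: in this assay compound 4 gives 38% as its maximal response, but its direct partner, compound 2, has no single number to set against it. No evidence bearing on this result is available. The compounds shown leave open how the fluoro on the aromatic carbon affects the maximal response.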